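Chain-lengthened amide in the sulfonate series

The compounds below may be only part of what the source reports. "The series", "measured", "known", "first", "only" and "open" are said of these compounds alone.

Compound 1 `CCC(=O)Nc1cccc(S(=O)(=O)Oc2ccccc2C(C)C)c1` and compound 2 `CC(C)C(=O)Nc1cccc(S(=O)(=O)Oc2ccccc2C(C)C)c1` share one core, in which the amide nitrogen and the sulfonate ester sit in one arrangement on the central ring; compound 3 `CCC(=O)Nc1ccc(S(=O)(=O)Oc2ccccc2C(C)C)cc1` and compound 4 `CCCC(=O)Nc1ccc(S(=O)(=O)Oc2ccccc2C(C)C)cc1` share another. The difference between the two cores is not broken down here. In a functional assay on HT-29 cells (Homo sapiens) for antiproliferative activity, read by sulforhodamine B assay, with a stated time of 48 h (a lower number here means a stronger inhibitor, a higher number a weaker inhibitor), compound 1 gives 22000 nM, compound 2 gives 16000 nM, and compound 3 gives 7400 nM, the lowest number of the three, with compound 2 the nearest and compound 1 the furthest of them.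

Within the first core the step of a 1.4-fold lower number from compound 1 to compound 2 (0.14 log units; within the scatter) belongs to the change (methyl in place of hydrogen on a saturated chain carbon bound to a carbonyl carbon and a saturated chain carbon). Compound 4 differs from compound 3 by methyl in place of hydrogen on a saturated chain carbon, two bonds along the chain from a carbonyl carbon. This is the same kind of change as from compound 1 to compound 2, a methyl in place of hydrogen on a saturated chain carbon, but it is not the same: in the first pair the carbon is bound to a carbonyl carbon and a saturated chain carbon, in the second pair it lies two bonds along the chain from a carbonyl carbon. Among the measured compounds shown here, only one such step is measured here, and it rests on the other core.

Given that compound 2 differs from compound 1 by a 1.4-fold lower number from compound 1 to compound 2 (0.14 log units; within the scatter), a step of about the same small size is expected for compound 4, a 1.2-fold lower number from compound 3 to compound 4 (0.09 log units; within the scatter). In this assay compound 4 is therefore estimated at 6000 nM, with a range from 2500 nM to 15000 nM.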

Compound 4, half-maximal inhibitory concentration: 4900 nM
Beside the measured number, compound 4's estimate is 1.2-fold (0.09 log units) above it; measured number inside the range.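

In this assay the added methyl leaves the number within the scatter on the second core as well, with a 1.5-fold lower number from compound 3 to compound 4 (0.18 log units; within the scatter), and the two steps agree when set side by side: the same change on two cores in this assay, a 1.4-fold lower number (0.14 log units; within the scatter) from compound 1 to compound 2 and a 1.5-fold lower number (0.18 log units; within the scatter) from compound 3 to compound 4, 1.1-fold (0.04 log units) apart, within the scatter of two such steps

On these two pairs, then, the change carries from one core to the other without a step beyond the scatter on either core, so the step measured on one core was a fair guide to the step on the other. This does not show that the methyl has any real effect on antiproliferative activity, and it does not establish a general rule of transfer: both steps lie within the scatter, each core supplies a single pair, and the methyl stands on a different chain carbon in each pair, bound to the carbonyl carbon's neighbouring position in neither the same way, so the match covers two related changes and not one identical change.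

Open, from the compounds shown here alone, is whether a longer chain on the amide, a cyclopropyl group or a chain ending in an amine or a carboxylic acid would move the number beyond the scatter. Also open, going by these compounds, is whether the agreement between the two cores would hold for such larger changes.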